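The compounds below may be only part of what the source reports. "The series", "measured", "known", "first", "only" and "open" are said of these compounds alone.

Compound 3 `ClCc1ccc(Cn2cnc3c(Cl)nc(Cl)nc32)cc1` and compound 1 `Nc1nc(Cl)c2ncn(Cc3ccc(CCl)cc3)c2n1` share a core and differ in one place. In a functional assay on HCT-116 cells (Homo sapiens) for cytotoxicity, read by sulforhodamine B assay, with a stated time of 48 h (a higher number here means a weaker inhibitor of growth, a lower number a stronger inhibitor of growth), compound 3 gives 1700 nM. In this assay compound 1 gives 2750 nM. The change between them is amino in place of chloro on an aromatic carbon and it made a step of a 1.6-fold higher number from compound 3 to compound 1 (0.21 log units; within the scatter).

Compound 2 `ClCc1cccc(Cn2cnc3c(Cl)nc(Cl)nc32)c1` has the same atoms as compound 3 joined differently; the difference between the two cores is not broken down here. In this assay compound 2 gives 1620 nM, which lies within the scatter of the values of compound 3 and compound 1.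

Compound 4 `Nc1nc(Cl)c2ncn(Cc3cccc(CCl)c3)c2n1` is not yet measured in this assay. It differs from compound 2 by amino in place of chloro on an aromatic carbon. This is the same change as that from compound 3 to compound 1, at a place described in the same words. The step from compound 2 to compound 4 in this assay is expected to be a 1.6-fold higher number from compound 2 to compound 4 (0.21 log units; within the scatter), resting on the step of a 1.6-fold higher number from compound 3 to compound 1 (0.21 log units; within the scatter) and on the value of compound 2, 1620 nM. Compound 4 is therefore estimated at 2600 nM, with a range from 1400 nM to 5000 nM.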

Compound 4, concentration for 50% growth inhibition: 1990 nM
The estimate for compound 4 lay 1.3-fold (0.12 log units) above the measured number, and the stated range covers the measured number.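

Amino in place of chloro on an aromatic carbon, between two ring nitrogen atoms, gives a 1.2-fold higher number from compound 2 to compound 4 (0.09 log units; within the scatter) in this assay and this can be set against the same change on the other core: the same change on two cores in this assay, a 1.6-fold higher number (0.21 log units; within the scatter) from compound 3 to compound 1 and a 1.2-fold higher number (0.09 log units; within the scatter) from compound 2 to compound 4, 1.3-fold (0.12 log units) apart, within the scatter of two such steps.

Across these four compounds the change therefore carries from one core to the other with no detectable difference, and neither step stands clear of the scatter. This does not show that the change has no effect in general or that it would transfer to further cores: two pairs with steps this small make only a weak test of transfer, since a step that stands clear of the scatter is not available for comparison.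

The compounds shown leave open whether another group on the same aromatic carbon, such as a methoxy group or a methylamino group, would give a step beyond the scatter. They also leave open how a longer chain or a carboxylic acid in place of the chloromethyl group would read in this assay and whether the amino step would hold there.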